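The compounds below may be only part of what the source reports. "The series", "measured", "known", "first", "only" and "open" are said of these compounds alone.

Measured compounds in a physicochemical assay for lipophilicity, at pH 7.4; a higher number here means a more lipophilic compound, a lower number a more polar compound:
compound 1, `CNC(=O)c1cc(C(=O)NCCCC2CNCCO2)cn(Cc2ccccc2)c1=O`, gives 1.4
compound 2, `CNC(=O)c1cc(C(=O)NC2CC2)cn(Cc2ccc3nc[nH]c3c2)c1=O`, gives 1.2
compound 3, `CNC(=O)c1cc(C(=O)NCCOC)cn(Cc2ccccc2)c1=O`, gives 2.7

Compound 2 sits with compound 1 at the polar end of the set; the values of compound 2 and compound 1 lie within the scatter of each other, so no order between the two can be read. Within the data shown here, compound 3 stands clearly apart from both, as the only measured step in this assay shows: a number 1.30 log units higher from compound 1 to compound 3 (beyond the scatter).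

Compound 4, `CNC(=O)c1cc(C(=O)NC2CC2)cn(Cc2cccc3cn[nH]c23)c1=O`, is still to be measured. The change from compound 2 is 1H-indazol-7-yl in place of 1H-benzimidazol-6-yl on a saturated chain carbon bound to an aromatic nitrogen. The two compounds are built from the same atoms, and neither donor nor acceptor count nor ring size changes.

Among the measured compounds shown here, the single measured step, from compound 1 to compound 3, concerns the amide-side chain and not the group on the saturated chain carbon bound to an aromatic nitrogen; it does not bear on the change to compound 4. For the measured compounds named here, no measured pair in the set varies this group. The expectation for compound 4 is therefore no step beyond the scatter, and the estimated step is a number 0.10 log units higher from compound 2 to compound 4 (within the scatter). Compound 4 is expected at 1.3, with a range from 0.9 to 1.7.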

Compound 4, distribution coefficient: 2.2
The estimate for compound 4 lay 0.90 log units below the measured number; measured number outside the range, above it.
By their numbers in this assay, from the lowest: compounds 2 and 1 (each within the scatter of the next); then compound 4; then compound 3.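

In this assay the place on a saturated chain carbon bound to an aromatic nitrogen proves sensitive to how the same atoms are joined, with a step beyond the scatter of a number 1.00 log units higher from compound 2 to compound 4 (beyond the scatter). 1H-benzimidazol-6-yl and 1H-indazol-7-yl have the same heavy atoms, the same kinds of ring and the same donor and acceptor counts, so these counts do not separate the two groups, whereas the earlier step in the series concerned only the amide-side chain and gave no reading of this place. No measurement in hand accounts for the size of this step.

With a single pair varying this place, the step cannot be assigned to the change from benzimidazolyl to indazolyl as such or to the change of attachment from 6-yl to 7-yl. Among these compounds, it also remains open whether a pyridyl group or a group carrying a carboxylic acid in the same place would give a number near compound 2 or near compound 4, and whether the step persists with another amide-side chain, such as the one in compound 3.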